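This account rests on a few compounds, and the source may have more. Where it says the series, first, only, none or still open, it means among the compounds named here.

Of the compounds shown here, three of a shared design have been measured in an assay on HEK293 cells for agonist activity at transient receptor potential cation channel subfamily M member 8 (Homo sapiens), read by fluorescence and calcium flux, with a stated time of 15 min; a higher number here means that more compound is needed for the effect, a lower number that less compound is needed. Compound 1, `CCN(Cc1ccoc1)C(=O)COc1ccc(C)cc1`, gives 136 nM. Compound 2, `Cc1ccc(OCC(=O)N(Cc2cccs2)C2CC2)cc1`, gives 8 nM. Compound 3, `CCN(Cc1cccs1)C(=O)COc1ccc(C#N)cc1`, gives 1990 nM. Among these three, compound 2 stands at the lowest number: compound 1 is its nearest neighbour and still lies beyond the scatter, while compound 3 lies furthest away, also beyond the scatter. Compound 2 is therefore the compound of this set that needs the least material for the effect.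

The next compound, compound 4, is `Cc1ccc(OCC(=O)N(Cc2cccs2)c2cn[nH]c2)cc1`. It keeps everything of compound 2 except one group on the amide-type nitrogen: 1H-pyrazol-4-yl in place of cyclopropyl on an amide-type nitrogen. Among the measured compounds shown here, because compound 2 gives 8 nM and no pair of compounds differing only at this nitrogen has been measured, the size of this step in this assay cannot be read from any earlier pair; an aromatic ring bearing a hydrogen-bond donor and acceptor is a considerable departure from the three-membered ring, and a step upward, beyond the scatter, is the expectation rather than no change. For compound 4 the estimated value is 100 nM, with a range from 15 nM to 800 nM. The expected step is a 13-fold higher number from compound 2 to compound 4 (1.10 log units; beyond the scatter).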

Compound 4, half-maximal effective concentration: 1.4 nM
For compound 4 the middle estimate is 71-fold (1.85 log units) above the measured one, outside the stated range (below it).
By their numbers in this assay, from the lowest: compound 4; then compound 2; then compound 1; then compound 3.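

Among the compounds shown here, at this amide-type nitrogen, 1H-pyrazol-4-yl in place of cyclopropyl gives a 5.7-fold lower number from compound 2 to compound 4 (0.76 log units; beyond the scatter) in this assay, the first direct reading of a change at this position, as no earlier pair differed only here. The position therefore accepts more than a three-membered non-aromatic ring of carbon only: a five-membered aromatic ring with 2 hetero atoms, carrying 1 hydrogen-bond donor and 1 hydrogen-bond acceptor, takes the place of cyclopropyl, and the number falls beyond the scatter. Nothing measured here accounts for this fall, so it stands as an observation on this single pair.

The compounds shown do not separate the contributions of the aromatic ring, the ring nitrogens and the hydrogen on the pyrazole, a question that a phenyl ring or a 1-methyl-1H-pyrazol-4-yl group on the same nitrogen would bear on. They also leave open whether the same change would lower the number to a similar extent with another partner on this nitrogen, such as furan-3-ylmethyl in place of thiophen-2-ylmethyl, or with a nitrile in place of the methyl group on the core.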